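Benzyl aryl swap on the crotonamide of the series

A few compounds are considered here, and "the series" means these few. Any claim that something is new, unique, unknown or untested is made for them only; others in the source may bear on it.

Compound 1 `C/C=C/C(=O)N(Cc1cccc(O)c1)c1cc(OC)c(OC)c(OC)c1` gives 6700 nM in a functional assay on HCT-116 cells (Homo sapiens) for inhibition, read by MTT assay, with a stated time of 48 h (a higher number here means a weaker inhibitor, a lower number a stronger inhibitor), the highest of the three numbers; compound 2 `CCC(=O)N(Cc1ccc(OC)c(O)c1)c1cc(OC)c(OC)c(OC)c1` gives 61 nM and compound 3 `C/C=C/C=C/C(=O)N(Cc1ccc(OC)c(O)c1)c1cc(OC)c(OC)c(OC)c1` gives 180 nM in this assay. Among the compounds with values here, the only single-point step measured is on the carbonyl side, a 3.0-fold higher number from compound 2 to compound 3 (0.47 log units; beyond the scatter), and does not touch the benzyl aryl. Compound 4 `C/C=C/C(=O)N(Cc1ccc(OC)c(C)c1)c1cc(OC)c(OC)c(OC)c1` differs from compound 1 by 4-methoxy-3-methylphenyl in place of 3-hydroxyphenyl on a saturated chain carbon bound to an amide-type nitrogen. Within the data shown here, no measured step bears directly on this change; compounds 2 and 3, which carry a 4-methoxy group on that ring, both sit far lower than compound 1, so a lower number is expected, with wide uncertainty: an 11-fold lower number from compound 1 to compound 4 (1.05 log units; beyond the scatter) is the estimated step. Compound 4 is expected to give 600 nM in this assay, between 120 nM and 3000 nM.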

Compound 4, half-maximal inhibitory concentration: 23500 nM
Estimate against measurement, compound 4: 39-fold (1.59 log units) below; the whole stated range lies below it.
By their numbers in this assay, from the lowest: compound 2; then compound 3; then compound 1; then compound 4.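

On the crotonamide, the change on a saturated chain carbon bound to an amide-type nitrogen gives a 3.5-fold higher number from compound 1 to compound 4 (0.54 log units; beyond the scatter) in this assay, so 4-methoxy-3-methylphenyl brings no gain over 3-hydroxyphenyl in this series member. This single step removes the hydrogen-bond donor and adds heavy atoms together, and it cannot separate the two. No evidence on the cause of the higher number is available. Open, from the compounds shown here alone, is how the crotonamide would respond to an amine in place of the methyl of 4-methoxy-3-methylphenyl.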